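A few compounds are considered here, and "the series" means these few. Any claim that something is new, unique, unknown or untested is made for them only; others in the source may bear on it.

Compound 1, `O=C1C=CS(=O)(=O)c2ccccc21`, gives 5.5% in a functional assay on the whole organism for inhibition, with Mus musculus as the target, at a dose of 10 mg/kg; on this read-out lower numbers stand for less inhibition and higher numbers for more inhibition at the one dose given (going by the name of the read-out). Compound 2, `CCCOCC1=CS(=O)(=O)c2ccccc2C1=O`, gives 99.9% in this assay; the step of a number 94.4 percentage points higher from compound 1 to compound 2 (beyond the scatter) came with propoxymethyl in place of hydrogen on a double-bonded ring carbon. Among the compounds with values here, of the two numbers known, compound 1 stands at the lower one, and compound 2 sits beyond the scatter above it. Compound 3, `CC(C)OCC1=CS(=O)(=O)c2ccccc2C1=O`, differs from compound 1 by isopropoxymethyl in place of hydrogen on a double-bonded ring carbon. Within the data shown here, the only measured step that bears on this change is the one from compound 1 to compound 2, which was large, and the group entering in compound 3 is a close relative of the group entering there. For compound 3 a rise in this assay is therefore expected, roughly matching that earlier step, as a number 84.5 percentage points higher from compound 1 to compound 3 (beyond the scatter). The estimate for compound 3 is 90%, with a range from 55% to 100%, since a single precedent leaves room for a smaller gain.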

Compound 3, a percentage reported as inhibition, in the whole organism at one dose (the size of the read-out at that dose, not a potency): 99.2%
Compound 3: the middle estimate sits 9.2 percentage points below what was measured; low and high end bracket the measured number.
By their numbers in this assay, from the lowest: compound 1; then compounds 3 and 2 (each within the scatter of the next).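

In this assay the large rise seen on this double-bonded ring carbon now holds for a second ether side chain, with isopropoxymethyl in place of hydrogen giving a number 93.7 percentage points higher from compound 1 to compound 3 (beyond the scatter) as the step. Branching the chain makes no difference that can be read: isopropyl in place of propyl on the oxygen gives a number 0.7 percentage points lower from compound 2 to compound 3 (within the scatter) as the step, so at this one dose the two side chains cannot be told apart. Nothing given here accounts for the rise or for the match between the two chains.

Compound 2 and compound 3 both lie close to the top of the scale, which leaves open whether the two would separate at a lower dose. Also open, from the compounds shown here alone, is whether the ether oxygen matters at all, and whether a plain butyl chain, an aminomethyl group or a carboxylic acid on the same carbon would give a comparable rise.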